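The source may hold more compounds than are shown below. What is called first, only, known or untested is meant among the compounds shown, and "the series" means these compounds.

Compound 1 `COC(=O)CCC(=O)Nc1cccc(OCc2ccc3ccccc3n2)c1` gives 28000 nM in an assay on isolated protein for inhibition of Polyunsaturated fatty acid 5-lipoxygenase (Rattus norvegicus); on this read-out higher numbers stand for weaker inhibition and lower numbers for stronger inhibition.
Compound 2 `COC(=O)CCC(=O)N(O)c1cccc(OCc2ccc3ccccc3n2)c1` gives 1400 nM in this assay.
Compound 3 `COC(=O)C(=O)Nc1cccc(OCc2ccc3ccccc3c2)c1` gives 6900 nM in this assay.

Among these three numbers compound 1 stands highest: compound 3 gives a lower number, and the change to the hydroxylated amide brings a 20-fold lower number from compound 1 to compound 2 (1.30 log units; beyond the scatter). Compound 4 `CCOC(=O)CCC(=O)Nc1cccc(OCc2ccc3ccccc3n2)c1` differs from compound 1 by methyl in place of hydrogen on a saturated chain carbon bound to an oxygen next to a carbonyl group. Within the data shown here, no measured step touches this place; the one recorded step alters the amide-type nitrogen and says nothing about the ester end of the chain. Compound 4 is therefore expected to show no step beyond the scatter in this assay, that is no change at the digits printed from compound 1 to compound 4 (within the scatter). Compound 4 is estimated at 28000 nM, in a range from 10000 nM to 80000 nM.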

Compound 4, half-maximal inhibitory concentration: 12600 nM
Beside the measured number, compound 4's estimate is 2.2-fold (0.35 log units) above it; the range from low to high includes it.
By their numbers in this assay, from the lowest: compound 2; then compounds 3 and 4 (each within the scatter of the next); then compound 1.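

Among these compounds, at the ester end of the chain, which the earlier compounds left untouched, the readout in this assay does respond: ethoxycarbonyl in place of methoxycarbonyl brings a 2.2-fold lower number from compound 1 to compound 4 (0.35 log units; beyond the scatter). This modest step is smaller than the change at the amide-type nitrogen, a 20-fold lower number from compound 1 to compound 2 (1.30 log units; beyond the scatter). Nothing given here bears on why the added methyl has this effect. As far as these compounds go, whether a longer chain on this oxygen would lower the number further stays open, as does the result of a carboxylic acid at this end. Also open, from the compounds shown here alone, is whether the ethyl ester and the hydroxy on the nitrogen would combine.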